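Trimming the benzofuran of compound 2 to a furan

The source may hold more compounds than are shown below. What is called first, only, known or untested is meant among the compounds shown, and "the series" means these compounds.

Measured so far:
Compound 1, `CN(CCCNC(=O)c1ccco1)Cc1ccccc1`: > 10000 nM
Compound 2, `COc1ccc(CN(C)CCCNC(=O)c2cc3ccccc3o2)cc1OC`: 375 nM

In an assay on isolated protein for binding affinity to Sigma non-opioid intracellular receptor 1 (Homo sapiens), read by radioligand binding (a lower number here means a stronger inhibitor, a higher number a weaker inhibitor), compound 1 reaches only a limit, (the limit of > 10000 nM in this assay, at which 1 of the 2 values shown sits), not a number. For the measured compounds named here, compound 2 is the only compound with a measured number here, 375 nM in this assay. Compound 3, `COc1ccc(CN(C)CCCNC(=O)c2ccco2)cc1OC`, differs from compound 2 by furan-2-yl in place of 1-benzofuran-2-yl on a carbonyl carbon. Compound 1 also carries a furan-2-yl and gives only a limit, so a loss of affinity is expected; the step of a 6.7-fold higher number from compound 2 to compound 3 (0.82 log units; beyond the scatter) is estimated to be beyond the scatter. Compound 3 is expected to give about 2500 nM, within 800 nM to 10000 nM.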

Compound 3, inhibition constant: > 10000 nM
Compound 3: only a limit was reported; the forecaster's own chance of this, stated with the estimate: 25%; at least 4.0-fold (0.60 log units) between middle value and limit.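

Compound 1 differs from compound 2 in more than one place, so it could not show what the 1-benzofuran-2-yl itself contributes. With only the group on the carbonyl carbon changed, this assay gives an at least 26-fold higher number from compound 2 to compound 3 (1.42 log units; beyond the scatter). Measurable binding in this pair therefore depends on the 1-benzofuran-2-yl, and furan-2-yl cannot replace it here.

On these data alone, compound 3 reaches only a limit, so the full size of the loss remains unknown: the limit of > 10000 nM in this assay, at which 2 of the 3 values shown sit. Whether an indol-2-yl or a 5-phenylfuran-2-yl group would restore binding also stays open.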